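Acetylenic imidazole carbamates and acetamides: notes before compound 4

A few compounds are considered here, and "the series" means these few. Any claim that something is new, unique, unknown or untested is made for them only; others in the source may bear on it.

Measured so far:
- compound 1 `CC(=O)NCC#CCn1ccnc1`: > 100 mg/kg
- compound 2 `CC(=O)NCC#CCn1cncc1C`: > 100 mg/kg
- compound 3 `COC(=O)N(C)C(C)C#CCn1ccnc1`: 6.6 mg/kg

In a functional assay on the whole organism for agonist activity, with Mus musculus as the target (a higher number here means that more compound is needed for the effect, a lower number that less compound is needed), compound 1 gives > 100 mg/kg, which is a limit of the assay and not a number. In this assay compound 2 likewise gives > 100 mg/kg, also a limit. The step between them, a step that the two limits leave unreadable from compound 1 to compound 2, is therefore unreadable: the change is methyl in place of hydrogen on an aromatic carbon, and its size cannot be taken from two limits. Within the data shown here, compound 3 is the only compound with a number, 6.6 mg/kg; the difference between the core of compound 3 and the core of compound 1 is not broken down here.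

Compound 4 `COC(=O)N(C)C(C)C#CCn1cncc1C` carries the same kind of change on the core of compound 3, (methyl in place of hydrogen on an aromatic carbon); the place differs only in that the ring atom bears a large group rather than a group of 8 heavy atoms. With the step from compound 1 to compound 2 unreadable, the expected step of a 1.4-fold higher number from compound 3 to compound 4 (0.13 log units; within the scatter) rests only on the value of compound 3 and is taken as small. Compound 4 is thus estimated at 9 mg/kg, expected between 3 mg/kg and 40 mg/kg.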

Compound 4, dose for half-maximal effect: 97 mg/kg
For compound 4 the middle estimate is 11-fold (1.03 log units) below the measured one; measured number above the stated range.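

In this assay, methyl in place of hydrogen on an aromatic carbon gives a 15-fold higher number from compound 3 to compound 4 (1.17 log units; beyond the scatter), so on the core of compound 3 this single change is large and more compound is needed once the methyl is present. The same change on the core of compound 1 cannot be read, and its step cannot be set beside the new one: the limit of > 100 mg/kg in this assay, at which 2 of the 4 values shown sit. Carrying the change from one core to another is therefore not shown to hold or to fail, and the one readable step gives neither a rule for the series nor a reason for its size.

The compounds shown leave open whether an ethyl or a chlorine on the same aromatic carbon would give a step of similar size on the core of compound 3. They also leave open how the methyl change reads on a core with an amine or a longer chain in place of the carbamate.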